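Nitro-bearing coumarin amide: methoxyphenyl replaced by methylphenyl

The compounds below may be only part of what the source reports. "The series", "measured", "known", "first", "only" and "open" are said of these compounds alone.

Measured compounds:
compound 1, `Cc1cccc(NC(=O)c2cc3ccccc3oc2=O)c1` — 930 nM
compound 2, `COc1ccccc1NC(=O)c1cc2cc([N+](=O)[O-])ccc2oc1=O` — 50000 nM

In an assay for inhibition of Amine oxidase [flavin-containing] B (Homo sapiens), read by fluorescence, using microsomes, with a stated time of 15 min (a higher number here means a weaker inhibitor, a lower number a stronger inhibitor), compound 1 gives 930 nM. Compound 2 gives 50000 nM in this assay, the highest of the two numbers and far beyond the scatter from compound 1. The two compounds differ in two places at once, in the aryl group on the amide nitrogen and in the nitro group on the shared core, so the numbers alone do not tell which change carries the gap.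

Compound 3, `Cc1cccc(NC(=O)c2cc3cc([N+](=O)[O-])ccc3oc2=O)c1`, has not yet been measured. It differs from compound 2 by 3-methylphenyl in place of 2-methoxyphenyl on an amide-type nitrogen. Compound 3 thus carries the aryl group of compound 1 together with the nitro group of compound 2. A lower number than compound 2 is expected, with an uncertain size. The gap between compound 1 and compound 2 cannot be split between the two changes from the two values alone. The estimate for compound 3 in this assay is 5000 nM, within 800 nM to 35000 nM. The expected step of a 10-fold lower number from compound 2 to compound 3 (1.00 log units; beyond the scatter) is a fall.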

Compound 3, half-maximal inhibitory concentration: 39100 nM
Estimate against measurement, compound 3: 7.8-fold (0.89 log units) below; measured number outside the range, above it.
By their numbers in this assay, from the lowest: compound 1; then compounds 3 and 2 (each within the scatter of the next).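

In this assay the exchange of 3-methylphenyl for 2-methoxyphenyl on an amide-type nitrogen gives a 1.3-fold lower number from compound 2 to compound 3 (0.11 log units; within the scatter) and so stays within the scatter, which shows that, with the nitro group on the shared core, these two aryl groups cannot be told apart by this read-out. With 3-methylphenyl held fixed, nitro in place of hydrogen on an aromatic carbon gives a 42-fold higher number from compound 1 to compound 3 (1.62 log units; beyond the scatter) and is a large step beyond the scatter, so the gap that compounds 1 and 2 left undivided can now be followed through a single change, and most of it lies with the nitro group. Nothing shown gives a reason for either step.

The compounds shown leave open whether the two aryl groups would also match on the core without the nitro group, since the exchange is seen only on the nitro-bearing core. They also leave open how an amine or a carboxylic acid at the place held by the nitro group would read, and whether the large step belongs to the nitro group alone or to any group at that carbon.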